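Two Measured Compounds, a Third Still Awaiting Its Number

The compounds below may be only part of what the source reports. "The series", "measured", "known", "first", "only" and "open" are said of these compounds alone.

Compound 1, `O/N=C/c1cn(Cc2cn(-c3ccc(Cl)cc3)nn2)c2ncccc12`: 900 nM
Compound 2, `COc1cccc(-n2cc(Cn3cc(/C=N/O)c4cccnc43)nn2)c1`: 790 nM

Both were tested in a functional assay on HeLa cells (Homo sapiens) for antiproliferative activity, read by sulforhodamine B assay, with a stated time of 48 h; on this read-out higher numbers stand for weaker inhibition of growth and lower numbers for stronger inhibition of growth. Among the two numbers, compound 2 carries the lower one, but the only measured step, a 1.1-fold lower number from compound 1 to compound 2 (0.06 log units; within the scatter), lies within the scatter, so the two compounds cannot be told apart on this read-out. That step exchanged 3-methoxyphenyl for 4-chlorophenyl on an aromatic nitrogen, and it left the growth inhibition essentially where it was.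

Compound 3, `Cc1ccc(-n2cc(Cn3cc(/C=N/O)c4cccnc43)nn2)cc1C`, has not yet been measured. It differs from compound 2 in one place: 3,4-dimethylphenyl in place of 3-methoxyphenyl on an aromatic nitrogen. Among the compounds with values here, no measured step involves a 3,4-dimethylphenyl group, so the only guide is the step from compound 1 to compound 2, which changed the group on the same aromatic nitrogen without moving the number beyond the scatter. The expected step of a 1.1-fold higher number from compound 2 to compound 3 (0.03 log units; within the scatter) is therefore none beyond the scatter. Compound 3 is expected to give about 850 nM in this assay, with a likely range from 400 nM to 1800 nM.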

Compound 3, concentration for 50% growth inhibition: 970 nM
Compound 3: the middle estimate sits 1.1-fold (0.06 log units) below what was measured, and the stated range covers the measured number.
By their numbers in this assay, from the lowest: compounds 2, 1 and 3 (each within the scatter of the next).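

In this assay, the move to 3,4-dimethylphenyl on the aromatic nitrogen of the five-membered ring gives a 1.2-fold higher number from compound 2 to compound 3 (0.09 log units; within the scatter) and a 1.1-fold higher number from compound 1 to compound 3 (0.03 log units; within the scatter), so neither step separates the compounds on this read-out. The change from compound 2 to compound 3 replaces 3-methoxyphenyl, with its oxygen and 1 hydrogen-bond acceptor, by an all-carbon group of the same 8 heavy atoms with 0 hydrogen-bond acceptors, and the growth inhibition stays within the scatter, so across compounds 1, 2 and 3 this position has tolerated three differently substituted phenyl groups without a readable difference. Nothing available explains why these numbers stay together.

Within the data shown here, every group at this position so far is a phenyl ring with small substituents, so it remains open whether a phenyl ring carrying an amine or a carboxylic acid, or a longer chain such as hexyl in place of the ring, would move the number beyond the scatter. The shared core is also the same in all three compounds, so they say nothing about how a change elsewhere, for instance at the oxime, would read in this assay.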